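Lipophilicity of a Pyrazinylamino Replacement for Methylpiperidine

The source may hold more compounds than are shown below. What is called first, only, known or untested is meant among the compounds shown, and "the series" means these compounds.

Compound 1 `CC1CCCN(Cc2c(-c3nnc(SC(C)C)n3-c3ccccc3)n(C)c3ccccc23)C1`: 6.03
Compound 2 `COc1ccc(CNCc2c(-c3nnc(SC(C)C)n3-c3ccccc3)n(C)c3ccc(F)cc23)cc1`: 6.42
Compound 3 `CC(C)Sc1nnc(-c2c(CNCC3CC3)c3cc(F)ccc3n2C)n1-c1ccccc1`: 5.4

In a physicochemical assay for lipophilicity (on this read-out higher numbers stand for higher lipophilicity and lower numbers for lower lipophilicity), compound 1 stands second highest of the three, with compound 2 higher and compound 3 lower, both gaps beyond the scatter. The unmeasured compound 4 `CC(C)Sc1nnc(-c2c(CNc3cnccn3)c3ccccc3n2C)n1-c1ccccc1` differs from compound 1 by (pyrazin-2-yl)amino in place of 3-methylpiperidin-1-yl on a saturated chain carbon bound to an aromatic carbon. Among the measured compounds shown here, no measured step matches this change exactly; the nearest is a number 1.02 log units lower from compound 2 to compound 3 (beyond the scatter), where a group on a carbon bound to an amine nitrogen was exchanged. That step was large, and the exchange here trades a saturated ring for an aromatic amino group with more acceptors and a donor, so a downward step is expected, a number 1.03 log units lower from compound 1 to compound 4 (beyond the scatter). Compound 4 is therefore estimated at 5, within 4.3 to 5.7.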

Compound 4, partition coefficient: 4.22
For compound 4 the middle estimate is 0.78 log units above the measured one; measured number outside the range, below it.
By their numbers in this assay, from the lowest: compound 4; then compound 3; then compound 1; then compound 2.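

In this assay, (pyrazin-2-yl)amino in place of 3-methylpiperidin-1-yl on a saturated chain carbon bound to an aromatic carbon gives a number 1.81 log units lower from compound 1 to compound 4 (beyond the scatter), the first change shown at this place. Both groups have the same heavy-atom count, so a large step appears here without any change in that count, which the earlier step did not show.

From the compounds shown here alone, how phenylamino or morpholin-4-yl would read at this place stays open, so the shares of the aromatic ring and the amino link in this step cannot be separated. No measured property of either group is available to account for the size of the step.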